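Working notes: the step from compound 3 to compound 4

A few compounds are considered here, and "the series" means these few. Any claim that something is new, unique, unknown or untested is made for them only; others in the source may bear on it.

In a functional assay on K562 cells (Homo sapiens) for inhibition (on this read-out lower numbers stand for stronger inhibition of growth and higher numbers for weaker inhibition of growth), compound 1 `Nc1nn2c(O)cc(CCl)nc2c1[N+](=O)[O-]` reaches only the limit > 50 ug/mL rather than a number. Compound 2 `NNCc1cc(O)n2nc(N)c([N+](=O)[O-])c2n1` gives 26.5 ug/mL in this assay. Compound 3 `Nc1nn2c(O)cc(CNNC(N)S)nc2c1[N+](=O)[O-]` likewise reaches only the limit > 50 ug/mL. The measured steps read an at least 1.8-fold lower number from compound 1 to compound 2 (0.27 log units; that floor lies within the scatter) and an at least 1.8-fold higher number from compound 2 to compound 3 (0.27 log units; that floor lies within the scatter), while a step that the two limits leave unreadable from compound 1 to compound 3. Compound 3 thus stands at the limit of > 50 ug/mL in this assay, at which 2 of the 3 values shown sit. Compound 4 `CCSC(N)NCc1cc(O)n2nc(N)c([N+](=O)[O-])c2n1` differs from compound 3 by amino(ethylsulfanyl)methyl in place of (amino(sulfanyl)methyl)amino on an amine nitrogen. Of the measured steps only an at least 1.8-fold higher number from compound 2 to compound 3 (0.27 log units; that floor lies within the scatter) touches this nitrogen, and it ran toward the limit, so a further group on the same nitrogen is expected to leave the number there; the estimated step is a number no higher from compound 3 to compound 4 (the limit leaves the size open). Compound 4 is expected at 50 ug/mL, between 25 ug/mL and 100 ug/mL.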

Compound 4, concentration for 50% growth inhibition: > 50 ug/mL
Compound 4 ended at the assay's limit (the forecaster's own chance of this, stated with the estimate: 65%); the middle value lies on the limit itself.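

In this assay compound 4 gives > 50 ug/mL, which is a limit and not a number. A second group on this amine nitrogen, amino(ethylsulfanyl)methyl, gives an at least 1.8-fold higher number from compound 2 to compound 4 (0.27 log units; that floor lies within the scatter), so compound 2 remains the only compound shown with a number. The steps from compound 3 to compound 4 and from compound 1 to compound 4 cannot be read, and the series gathers at one limit: the limit of > 50 ug/mL in this assay, at which 3 of the 4 values shown sit.

From the compounds shown here alone, how far compound 3 and compound 4 lie past the limit stays open, so their groups cannot be ranked. Going by these compounds, whether a methyl or an acetyl group on this amine nitrogen would keep a readable number also stays open.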